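This account rests on a few compounds, and the source may have more. Where it says the series, first, only, none or still open, it means among the compounds named here.

Series notes, values in a functional assay on OVCAR-5 cells (Homo sapiens) for inhibition, with a stated time of 48 h, tested at 50 uM (on this read-out higher numbers stand for more inhibition of growth at the one concentration tested and lower numbers for less inhibition of growth), as follows

- compound 1 `C=C[C@@](C)(/C=C/c1ccc(O)c(N)c1)CCC=C(C)C` gives 33%
- compound 2 `C=C[C@@](C)(/C=C/c1ccc(O)cc1)CC/C=C(/C)C=O` gives 22%
- compound 3 `COc1ccccc1/C=C/[C@@](C)(/C=C/c1ccc(O)cc1)CCC=C(C)C` gives 38%

In this assay compound 3 stands at 38% and is the reference point for the next step. Compound 1 at 33% lies within the scatter of that figure, so the two cannot be ranked. Compound 2 at 22% lies beyond the scatter under compound 3. For the measured compounds named here, all three readings come from one concentration, and none of the measured compounds differ in one place only.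

The next compound is compound 4 `COc1ccc(/C=C/[C@@](C)(/C=C/c2ccc(O)cc2)CCC=C(C)C)cc1`, still unmeasured. Its change from compound 3 is 4-methoxyphenyl in place of 2-methoxyphenyl on a double-bonded chain carbon bound to a double-bonded chain carbon. The two structures hold the same atoms, and only the 2-methoxyphenyl gives way to the 4-methoxyphenyl on a double-bonded chain carbon bound to a double-bonded chain carbon.

Going by the values given here, no measured pair shows what such a change does, so the only anchor is compound 3 at 38% and no step beyond the scatter is expected. The expected move is a number 1 percentage points lower from compound 3 to compound 4 (within the scatter) and it stays within the scatter, with no direction favoured. For compound 4 the estimated value is 37%, with an expected range from 24% to 50%.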

Compound 4, percent growth inhibition at one concentration: 20%
Compound 4: middle estimate off by 17 percentage points, on the high side, and the stated range ends above it.
By their numbers in this assay, from the lowest: compounds 4 and 2 (each within the scatter of the next); then compounds 1 and 3 (each within the scatter of the next).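

In this assay, for the compounds shown here, the first comparison that differs in one place gives a number 18 percentage points lower from compound 3 to compound 4 (beyond the scatter), with 4-methoxyphenyl in place of 2-methoxyphenyl on a double-bonded chain carbon bound to a double-bonded chain carbon. The earlier compounds shown here gave no reading of this position, and this pair shows that the read-out can respond to a change that leaves the atoms the same, since the two groups also match in heavy atoms, aromatic ring, hydrogen-bond donors and acceptors, and charge. The counted features therefore do not separate compound 3 from compound 4, and no measurement shown here accounts for the step.

From the compounds shown here alone, whether a plain phenyl, a 4-chlorophenyl or a 4-carboxyphenyl at the same place would read nearer to compound 3 or to compound 4 remains open, so a single pair cannot yet define a trend at this position. Also open, going by these compounds, is whether the step would persist across a range of concentrations, as every reading here comes from one concentration.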